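A Fluoro-to-Imino Swap on the Piperidine Ring

The compounds below may be only part of what the source reports. "The series", "measured", "known", "first", "only" and "open" are said of these compounds alone.

compound 1: `CC1CCN(S(=O)(=O)c2ccc(NC(=O)c3ccc([N+](=O)[O-])o3)cc2)CC1` — > 25000 nM
compound 2: `O=C(Nc1ccc(S(=O)(=O)N2CCC(F)CC2)cc1)c1ccc([N+](=O)[O-])o1` — > 25000 nM

In an ADME assay on IMR-90 cells (Homo sapiens) for cytotoxicity, read by CellTiter-Blue, with a stated time of 46 h (a lower number here means that less compound is needed, a higher number that more compound is needed for the effect), compound 1 gives > 25000 nM, which is a limit of the assay rather than a number. Compound 2 in turn gives > 25000 nM, again a limit. The step that the two limits leave unreadable from compound 1 to compound 2 is therefore of unreadable size. Compound 2 thus stands only at a limit, and the limit of > 25000 nM in this assay, at which 2 of the 2 values shown sit, shows that both measured values sit at that same limit.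

Compound 3, `N=C1CCN(S(=O)(=O)c2ccc(NC(=O)c3ccc([N+](=O)[O-])o3)cc2)CC1`, differs from compound 2 by 4-iminopiperidin-1-yl in place of 4-fluoropiperidin-1-yl on a sulfonyl sulfur. Within the data shown here, no measured step covers this change, and the one step between the measured compounds gives no readable size or direction. With both measured compounds at the limit, compound 3 is expected to remain there as well. Compound 3 is estimated at 30000 nM, with a range from 10000 nM to 100000 nM. This corresponds to an expected step that the limit leaves unreadable from compound 2 to compound 3 of no readable size.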

Compound 3, half-maximal effective concentration: > 25000 nM
Compound 3 ended at the assay's limit; the forecaster's own chance of this, stated with the estimate: 70%; the middle value does not contradict the limit.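

In this assay compound 3 gives > 25000 nM as a limit of the assay. Among these compounds, no step among compound 1, compound 2 and compound 3 can be read, because all three rest at one limit: the limit of > 25000 nM in this assay, at which 3 of the 3 values shown sit. The compounds shown leave open how much of each is needed for the effect, and whether these groups differ at all.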